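Working notes: methyl in place of chloro

The source may hold more compounds than are shown below. What is called first, only, known or untested is meant among the compounds shown, and "the series" means these compounds.

Values from a functional assay on NCI-H460 cells (Homo sapiens) for inhibition, read by MTT assay, with a stated time of 24 h, tested at 10 ug/mL (on this read-out higher numbers stand for more inhibition of growth at the one concentration tested and lower numbers for less inhibition of growth), follow
- compound 1 `O=C(CCCCC1CCSS1)NO` gives "not active" (no number reported)
- compound 2 `O=C(CCCCC(S)CCS)Nc1cccc(Cl)c1` gives "not active" (no number reported)
- compound 3 `O=C(CCCCC(S)CCS)Nc1ccc([N+](=O)[O-])c(C(F)(F)F)c1` gives 0.97%

Compound 2 carries no single number ("not active" (no number reported)), and compound 1 is the one further entry without a number. The next step leads to compound 4 `Cc1cccc(NC(=O)CCCCC(S)CCS)c1` with this change (methyl in place of chloro on an aromatic carbon): methyl in place of chloro on an aromatic carbon, meta to a large group. Going by the values given here, no measured pair shows a step at this place. In this assay no step beyond the scatter is expected, and another report without a number is quite possible. This expectation rests on compound 2 ("not active" (no number reported)) and compound 3 (0.97%), neither of which shows appreciable inhibition. For compound 4 the expected value is 2% (estimated range 0% to 12%).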

Compound 4, percent growth inhibition at one concentration: 7.67%
Beside the measured number, compound 4's estimate is 5.7 percentage points below it; measured number inside the range.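

In this assay, going by these compounds alone, compound 4 gives 7.67% and compound 2 gives "not active" (no number reported) so no step between these two compounds can be read. The compounds shown leave open whether methyl in place of chloro changes growth inhibition. No evidence at hand bears on this result.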